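Carbamoyl on the chain carbon: expected effect on maximal response

The compounds below may be only part of what the source reports. "The series", "measured", "known", "first", "only" and "open" are said of these compounds alone.

Of the compounds shown here, three built on a shared core have been measured in a functional assay on the whole organism (B cells) with Mus musculus as the target; on this read-out lower numbers stand for smaller maximal responses and higher numbers for larger maximal responses. Compound 1, `[N-]=[N+]=NCC(O)Cn1c(=O)n(C2OC(CO)[C@@H](O)[C@H]2O)c2nc(N)nc(O)c21`, gives 91% in this assay. Compound 2, `COc1ccc(Cn2c(=O)n(C3OC(CO)[C@@H](O)[C@H]3O)c3nc(N)nc(O)c32)cc1`, gives 44%. Compound 3, `Cn1c(=O)n(C2OC(CO)[C@@H](O)[C@H]2O)c2nc(N)nc(O)c21`, gives 99%, the highest of the three numbers, though its gap to compound 1 lies within the scatter: a number 8 percentage points higher from compound 1 to compound 3 (within the scatter). The gap to compound 2 is far larger: a number 55 percentage points higher from compound 2 to compound 3 (beyond the scatter).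

Compound 4, `NC(=O)Cn1c(=O)n(C2OC(CO)[C@@H](O)[C@H]2O)c2nc(N)nc(O)c21`, has not yet been measured in this assay. It differs from compound 3 in one place: carbamoyl in place of hydrogen on a saturated chain carbon bound to an aromatic nitrogen. The entering group has no ring, in contrast with the 4-methoxyphenyl of compound 2, and in size and in its donor and acceptor count it sits closer to the 2-azido-1-hydroxyethyl group of compound 1. Within the data shown here, two measured steps bear on this change. The step of a number 55 percentage points higher from compound 2 to compound 3 (beyond the scatter) shows that a ring-bearing group on the saturated chain carbon bound to an aromatic nitrogen goes with a much smaller maximal response. The step of a number 8 percentage points higher from compound 1 to compound 3 (within the scatter) shows that a small chain group without a ring leaves the number within the scatter. On that basis a small step is expected for compound 4, a number 9 percentage points lower from compound 3 to compound 4 (within the scatter), most likely within the scatter. Compound 4 is therefore estimated at 90%, with a range from 72% to 104%.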

Compound 4, largest response reached (reported as maximal response), in percent of the reference or control that the assay uses: 32%
Compound 4: middle estimate off by 58 percentage points, on the high side; the measured number lies below the stated range.
By their numbers in this assay, from the lowest: compound 4; then compound 2; then compounds 1 and 3 (each within the scatter of the next).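

In this assay, carbamoyl on the saturated chain carbon bound to an aromatic nitrogen gives a number 67 percentage points lower from compound 3 to compound 4 (beyond the scatter) and so shows that a group without a ring can also go with a much smaller maximal response. The comparison between two ringless groups points the same way: a number 59 percentage points lower from compound 1 to compound 4 (beyond the scatter) means that the absence of a ring does not by itself keep the number high at this position. A ring is also not needed for the lowest number of the series, since replacing 4-methoxyphenyl with carbamoyl gives a number 12 percentage points lower from compound 2 to compound 4 (beyond the scatter) and places the ringless group lower by a modest step. No measurement at hand gives a reason for these steps.

The compounds shown leave open whether a carboxylic acid, an amine or a methyl ester in place of carbamoyl would stay low like compound 4 or rise to the numbers of compound 1 and compound 3. They also leave open whether a longer chain ending in carbamoyl would keep the low number seen here.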